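The compounds below may be only part of what the source reports. "The series", "measured", "known", "first", "only" and "open" are said of these compounds alone.

In an ADME assay on L929 cells (Mus musculus) for cytotoxicity, read by resazurin assay, with a stated time of 72 h (on this read-out lower numbers stand for stronger inhibition and higher numbers for weaker inhibition), compound 1 `COCOc1cccc(C(=O)/C=C/c2ccc3c(c2)B(O)OC3)c1` is reported only as a limit, > 10 ug/mL, and not as a number. Compound 3 `COc1cccc(C(=O)CCc2ccc3c(c2)B(O)OC3)c1` likewise gives only a limit, > 10 ug/mL. Compound 2 `O=C(/C=C/c1ccc2c(c1)B(O)OC2)c1ccc(OCc2ccccc2)cc1` stands at the same point, giving only the limit > 10 ug/mL in this assay. Going by the values given here, all three measured compounds thus sit together at the limit of > 10 ug/mL in this assay, at which 3 of the 3 values shown sit, and no step between measured compounds can be resolved, since every value is a limit. Compound 4 `CCOC(=O)c1ccc(C(=O)/C=C/c2ccc3c(c2)B(O)OC3)cc1` differs from compound 2 by ethoxycarbonyl in place of benzyloxy on an aromatic carbon. Among the compounds with values here, nothing among the measured compounds points to a change, so the expected step, a number no higher from compound 2 to compound 4 (the limit leaves the size open), lies within the scatter. Compound 4 is therefore estimated to give 10 ug/mL, with a range from 5 ug/mL to 30 ug/mL, most likely again reported only as a limit.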

Compound 4, half-maximal inhibitory concentration: > 10 ug/mL
Compound 4: no number, only a limit; the forecaster's own chance of this, stated with the estimate: 80%; the middle value lies on the limit itself.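

Compound 2 and compound 4 are both reported only as limits in this assay, so no step can be read between them: the limit of > 10 ug/mL in this assay, at which 4 of the 4 values shown sit.

The compounds shown leave open whether ethoxycarbonyl and benzyloxy differ at all on this read-out.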